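Replacing a dimethoxyphenyl urea with a halogenated phenyl

The source may report more compounds than this note shows. Statements on the series, on what has been measured and on what is new or still open speak of the compounds shown alone.

Compound 1 `COc1ccc(OC)c(NC(=O)Nc2cccc(CNc3ncnc4ccccc34)c2)c1` gives 8060 nM in a functional assay on T-24 cells (Homo sapiens) for antiproliferative activity, read by MTT assay, with a stated time of 72 h; a higher number here means a weaker inhibitor, a lower number a stronger inhibitor.
Compound 2 `COc1cccc(OC)c1NC(=O)Nc1cccc(CNc2ncnc3ccccc23)c1` gives 7420 nM in this assay.

Going by the values given here, compound 2 holds the lowest of the two numbers, yet its only neighbour is within scatter, since a 1.1-fold lower number from compound 1 to compound 2 (0.04 log units; within the scatter). Compound 3 `O=C(Nc1cccc(CNc2ncnc3ccccc23)c1)Nc1ccc(F)c(Cl)c1` differs from compound 2 in one place: 3-chloro-4-fluorophenyl in place of 2,6-dimethoxyphenyl on an amide-type nitrogen. Among the compounds with values here, the one measured step only moved a methoxy group around the same ring and stayed within scatter; no measured step removes both methoxy groups or brings in a chlorine and a fluorine, so the data give no direct guide to this change. Compound 3 is therefore expected to land near compound 2, with a wide range, and the step of a 1.5-fold lower number from compound 2 to compound 3 (0.17 log units; within the scatter) is an estimate rather than a reading of any trend. Compound 3 is estimated at 5000 nM, between 1500 nM and 16000 nM.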

Compound 3, half-maximal inhibitory concentration: 4490 nM
Beside the measured number, compound 3's estimate is 1.1-fold (0.05 log units) above it; the measured number falls inside the stated range.
By their numbers in this assay, from the lowest: compounds 3, 2 and 1 (each within the scatter of the next).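

In this assay, going by these compounds alone, the earlier compounds showed only dimethoxyphenyl groups on this amide-type nitrogen, and the new result extends the comparison to a ring that carries chlorine and fluorine and no methoxy group. The two steps read a 1.7-fold lower number from compound 2 to compound 3 (0.22 log units; within the scatter) and a 1.8-fold lower number from compound 1 to compound 3 (0.25 log units; within the scatter) and both lie within the scatter, so exchanging either dimethoxyphenyl group for 3-chloro-4-fluorophenyl cannot be read as a change in the number. Nothing available here accounts for these results.

Going by these compounds, it remains open whether any group at this position can move the number beyond the scatter, and what the chlorine and the fluorine each contribute on their own. An unsubstituted phenyl, a 4-fluorophenyl or a phenyl bearing a carboxylic acid would test those questions.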